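A few compounds are considered here, and "the series" means these few. Any claim that something is new, unique, unknown or untested is made for them only; others in the source may bear on it.

Measured in an ADME assay (liver) for metabolic stability, with Liver microsome (Homo sapiens) as the target, using microsomes and NADPH, with a stated time of 30 min, tested at 1 uM; a higher number here means faster removal of the compound, a lower number slower removal:
- Compound 1 `Nc1ccc(S(=O)(=O)N2CCN(c3ncc(C(O)(C(F)(F)F)C(F)(F)F)cc3C#CCCO)CC2)cn1`: < 14 mL.min-1.g-1, a limit of the assay
- Compound 2 `CC(C)n1cc(-c2cc(C(O)(C(F)(F)F)C(F)(F)F)cnc2N2CCN(S(=O)(=O)c3ccc(N)nc3)CC2)cn1`: 38 mL.min-1.g-1
- Compound 3 `Cc1csc(-c2cc(C(O)(C(F)(F)F)C(F)(F)F)cnc2N2CCN(S(=O)(=O)c3ccc(N)nc3)CC2)c1`: 29 mL.min-1.g-1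

Among the compounds with values here, compound 3 stands within the scatter of compound 2, the only other compound with a number: a 1.3-fold lower number from compound 2 to compound 3 (0.12 log units; within the scatter). Compound 1 is reported only as a limit, (the limit of < 14 mL.min-1.g-1 in this assay, at which 1 of the 3 values shown sits).

Compound 4 `Nc1ccc(S(=O)(=O)N2CCN(c3ncc(C(O)(C(F)(F)F)C(F)(F)F)cc3-c3cccc(F)c3)CC2)cn1` carries 3-fluorophenyl in place of 4-methylthiophen-2-yl on an aromatic carbon, ortho to a large group (3-fluorophenyl in place of 4-methylthiophen-2-yl on an aromatic carbon).

The closest measured change is the exchange of 1-isopropyl-1H-pyrazol-4-yl for 4-methylthiophen-2-yl at the same place, a 1.3-fold lower number from compound 2 to compound 3 (0.12 log units; within the scatter). The replacements of 4-hydroxybut-1-yn-1-yl are larger, an at least 2.7-fold higher number from compound 1 to compound 2 (0.43 log units; beyond the scatter) and an at least 2.0-fold higher number from compound 1 to compound 3 (0.31 log units; beyond the scatter), but they start from a different kind of group and bear less directly on this change. Within the data shown here, no measured compound carries 3-fluorophenyl, so the expectation rests on a single close step.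

The expected change is a 1.1-fold higher number from compound 3 to compound 4 (0.04 log units; within the scatter), which would not go beyond the scatter.

For compound 4 the estimated value is 32 mL.min-1.g-1, with an expected range of 18 mL.min-1.g-1 to 58 mL.min-1.g-1.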

Compound 4, intrinsic clearance in microsomes: 25 mL.min-1.g-1
Compound 4: middle estimate off by 1.3-fold (0.11 log units), on the high side; low and high end bracket the measured number.
By their numbers in this assay, from the lowest: compounds 4, 3 and 2 (each within the scatter of the next). At a limit, below all of these: compound 1.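

In this assay, 3-fluorophenyl, a six-membered aromatic ring of carbon only, reads the same at this position as the two five-membered aromatic rings with hetero atoms (a 1.2-fold lower number from compound 3 to compound 4 (0.06 log units; within the scatter); a 1.5-fold lower number from compound 2 to compound 4 (0.18 log units; within the scatter)), so across compounds 2, 3 and 4 neither ring size nor the presence of a hetero atom separates the values. Unlike compounds 2 and 3, compound 4 cannot be placed beyond the scatter from the 4-hydroxybut-1-yn-1-yl compound (an at least 1.7-fold higher number from compound 1 to compound 4 (0.25 log units; that floor lies within the scatter)). The value of compound 1 remains a limit: the limit of < 14 mL.min-1.g-1 in this assay, at which 1 of the 4 values shown sits.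

How far compound 1 actually lies from compounds 2, 3 and 4 stays undetermined. Also open, from the compounds shown here alone, is whether an amine or a carboxylic acid on the ring at this position, or a longer chain ending in a hydroxyl group, would give a number beyond the scatter of these three.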